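The source may report more compounds than this note shows. Statements on the series, on what has been measured and on what is new or still open speak of the compounds shown alone.

Three compounds share one core and differ only in the amine attached to a carbonyl carbon. Compound 1 `CC(C)c1cccc(C(C)C)c1NC(=O)NC(=O)N(Cc1ccccc1)Cc1ccccc1` carries a dibenzylamino group, and in an assay on microsomes from intestine for inhibition of acyl-CoA:cholesterol acyltransferase (Oryctolagus cuniculus) (a higher number here means a weaker inhibitor, a lower number a stronger inhibitor), compound 1 gives 1040 nM. Compound 2 `CCN(CC)C(=O)NC(=O)Nc1c(C(C)C)cccc1C(C)C` carries a diethylamino group; in this assay compound 2 gives only a limit, > 5000 nM. Compound 3 `CC(C)c1cccc(C(C)C)c1NC(=O)NC(=O)N1CCCC1` carries a pyrrolidin-1-yl group; in this assay compound 3 likewise gives only a limit, > 5000 nM. The step from one to the other is therefore a step that the two limits leave unreadable from compound 2 to compound 3. Compound 3 thus stands at the weak end of what has been measured, and it is not alone there: the limit of > 5000 nM in this assay, at which 2 of the 3 values shown sit.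

Compound 4 `CCCCN(CCCC)C(=O)NC(=O)Nc1c(C(C)C)cccc1C(C)C` is the next variation: dibutylamino in place of pyrrolidin-1-yl on a carbonyl carbon. Among the compounds with values here, no measured step covers this change directly. Within the data shown here, the single measured step, a step that the two limits leave unreadable from compound 2 to compound 3, cannot be sized, and it joins two small amines. Compound 1, whose dibenzylamino group is the largest of the three amines, gives 1040 nM, a number rather than a limit. The dibutylamino group of compound 4 is larger than pyrrolidin-1-yl but smaller than dibenzylamino, so a modest gain over compound 3 in this assay is expected, with a fair chance that only a limit is reported again. For compound 4 the expected value in this assay is 3000 nM, between 800 nM and 10000 nM. That amounts to an expected step of an at least 1.6-fold lower number from compound 3 to compound 4 (0.22 log units; that floor lies within the scatter).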

Compound 4, half-maximal inhibitory concentration: 250 nM
For compound 4 the middle estimate is 12-fold (1.08 log units) above the measured one; the whole stated range lies above it.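

In this assay, the amine on a carbonyl carbon now turns out to matter a great deal: dibutylamino in place of pyrrolidin-1-yl gives an at least 20-fold lower number from compound 3 to compound 4 (1.30 log units; beyond the scatter), and dibutylamino in place of diethylamino gives an at least 20-fold lower number from compound 2 to compound 4 (1.30 log units; beyond the scatter). Within the data shown here, until now, the only number at this position came from the dibenzylamino group, yet compound 4 gives 250 nM, a lower number than compound 1 at 1040 nM, so two open butyl chains can do better than the two benzyl groups here. The diethylamino and pyrrolidin-1-yl groups of compound 2 and compound 3 remain behind a limit of the assay rather than a number: the limit of > 5000 nM in this assay, at which 2 of the 4 values shown sit.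

The compounds shown leave open how the value follows chain length, since dipropylamino would sit in the gap in the series and dipentylamino or dihexylamino would show whether chains longer than butyl keep the gain. They also leave open whether two chains are needed at all, a question that a single butylamino group could answer, and whether a larger ring such as piperidin-1-yl or azepan-1-yl would escape the limit seen with pyrrolidin-1-yl.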